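The source may hold more compounds than are shown below. What is called first, only, known or untested is meant among the compounds shown, and "the series" means these compounds.

Measured so far:
compound 1, `CN(C)/C=C/N1CCN(CC(=O)Nc2ccc(-c3nc(-c4ccccc4)c(-c4ccccc4)n3C)cc2)CC1`: 8%
compound 2, `COc1ccc(CN2CCN(CC(=O)Nc3ccc(-c4nc(-c5ccccc5)c(-c5ccccc5)n4C)cc3)CC2)cc1`: 10.1%

Among the measured compounds shown here, compound 2 stands highest of the two numbers in a functional assay on HT-29 cells (Homo sapiens) for cytotoxicity, read by MTT assay, with a stated time of 24 h, tested at 1.6 ug/mL (on this read-out lower numbers stand for a weaker effect and higher numbers for a stronger effect at the one concentration tested), though its only neighbour, compound 1, lies within the scatter of it: a number 2.1 percentage points higher from compound 1 to compound 2 (within the scatter). Compound 3, `Cn1c(-c2ccc(NC(=O)CN3CCN(Cc4ccc(Cl)cc4)CC3)cc2)nc(-c2ccccc2)c1-c1ccccc1`, differs from compound 2 by chloro in place of methoxy on an aromatic carbon. For the measured compounds named here, the single measured step, a number 2.1 percentage points higher from compound 1 to compound 2 (within the scatter), changed a different part of the molecule and gives no direct guide to a chloro-for-methoxy exchange; both measured values are low. Compound 3 is therefore expected to stay near compound 2, a step of a number 0.1 percentage points lower from compound 2 to compound 3 (within the scatter) within the scatter, with an estimate of 10% ranging from 2% to 22%.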

Compound 3, a percentage reported as activity, at one concentration (the size of the read-out at that concentration, not a potency): 16.4%
The estimate for compound 3 lay 6.4 percentage points below the measured number; measured number inside the range.
By their numbers in this assay, from the lowest: compounds 1, 2 and 3 (each within the scatter of the next).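

In this assay, chloro in place of methoxy on the aromatic carbon para to a large group gives a number 6.3 percentage points higher from compound 2 to compound 3 (within the scatter), so this exchange does not separate the two compounds. Putting 4-chlorobenzyl in place of 2-(dimethylamino)ethenyl on the ring amine nitrogen gives a number 8.4 percentage points higher from compound 1 to compound 3 (within the scatter), so no step among these compounds lies beyond the scatter. Nothing available bears on the cause of this result.

The compounds shown leave open whether bromo, trifluoromethyl or an amine at this ring carbon would give a step beyond the scatter. They also leave open what an unsubstituted benzyl on the same nitrogen would give.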